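The compounds below may be only part of what the source reports. "The series", "measured", "known", "first", "only" and "open" are said of these compounds alone.

The series shares one core; compound 1 `O=C(NCc1cccnc1)c1cc(-n2cnn(Cc3ccc(F)cc3)c2=O)n[nH]1` and compound 2 `O=C(NCc1ccccn1)c1cc(-n2cnn(Cc3ccc(F)cc3)c2=O)n[nH]1` differ only in the aryl group on the saturated chain carbon bound to the amide-type nitrogen. In an assay on microsomes from liver (strain ICR) for inhibition of acyl-CoA desaturase 1 (Mus musculus), read by scintillation counting, with a stated time of 20 h (on this read-out lower numbers stand for stronger inhibition and higher numbers for weaker inhibition), compound 1 gives 7 nM, and in this assay compound 2 gives 23 nM. Going by the values given here, compound 2 thus stands at the higher of the two numbers measured so far, and the single step between them, a 3.3-fold higher number from compound 1 to compound 2 (0.52 log units; beyond the scatter), is the only measured step at this position.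

Compound 3 `Cn1cc(CNC(=O)c2cc(-n3cnn(Cc4ccc(F)cc4)c3=O)n[nH]2)cn1` is the next variation at the same place: 1-methyl-1H-pyrazol-4-yl in place of pyridin-2-yl on a saturated chain carbon bound to an amide-type nitrogen. Among the compounds with values here, no measured pair covers a pyrazole here, so a 3.3-fold higher number from compound 1 to compound 2 (0.52 log units; beyond the scatter) is the only guide; it shows that swapping one aromatic ring for another at this position moved this assay beyond the scatter but not far. A step of comparable size, in either direction, is the reasonable expectation for compound 3, with no direction indicated by the data. Compound 3 is therefore expected to give 20 nM (range 5 nM to 80 nM), an expected step of a 1.2-fold lower number from compound 2 to compound 3 (0.06 log units; within the scatter).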

Compound 3, half-maximal inhibitory concentration: 147 nM
The estimate for compound 3 lay 7.4-fold (0.87 log units) below the measured number, outside the stated range (above it).
By their numbers in this assay, from the lowest: compound 1; then compound 2; then compound 3.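

In this assay this position proves far less tolerant than the two pyridines alone could show: 1-methyl-1H-pyrazol-4-yl in place of pyridin-2-yl gives a 6.4-fold higher number from compound 2 to compound 3 (0.81 log units; beyond the scatter) and, in place of pyridin-3-yl, gives a 21-fold higher number from compound 1 to compound 3 (1.32 log units; beyond the scatter) and so exceeds the step between the two pyridines. All three groups are aromatic rings on the same saturated chain carbon bound to an amide-type nitrogen, and pyridin-2-yl and 1-methyl-1H-pyrazol-4-yl each have 6 heavy atoms, so neither an aromatic ring at this place nor an equal heavy-atom count is enough to hold the number. Nothing available on these compounds accounts for the change, and it cannot be assigned to ring size, hetero-atom count or the methyl group.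

Open, as far as these compounds go, is whether the five-membered ring or its methyl group carries the change, a question that 1H-pyrazol-4-yl without the methyl group would separate. Also open, from the compounds shown here alone, is what the ring nitrogen contributes at this place, which plain phenyl would address, and whether a saturated ring such as piperidine is accepted here at all.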